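Triazole substituent swap on the chromene core

The source may hold more compounds than are shown below. What is called first, only, known or untested is meant among the compounds shown, and "the series" means these compounds.

Measured compounds:
compound 1, `CCOC(=O)C1=Cc2ccccc2OC1(OCc1cn(CC(=O)Nc2cccc(Cl)c2)nn1)C(F)(F)F` — 12800 nM in a functional assay on A549 cells (Homo sapiens) for inhibition, read by MTT assay, with a stated time of 24 h; on this read-out higher numbers stand for weaker inhibition and lower numbers for stronger inhibition
compound 2, `CCOC(=O)C1=Cc2ccccc2OC1(OCc1cc(-c2ccc(OC)cc2)no1)C(F)(F)F` — > 150000 nM in this assay

In this assay, within the data shown here, compound 1 gives 12800 nM, the only actual number among the two values shown. For compound 2 the result in this assay is a limit, > 150000 nM, and not a number; it is the limit of > 150000 nM in this assay, at which 1 of the 2 values shown sits. Among the measured compounds shown here, compound 1 therefore stands as the one compound with a measured number, with no step between measured compounds to set a scale for the effect of any change.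

Compound 3, `CCOC(=O)C1=Cc2ccccc2OC1(OCc1cn(-c2ccc(F)c(Cl)c2)nn1)C(F)(F)F`, differs from compound 1 in one place: 3-chloro-4-fluorophenyl in place of ((3-chlorophenyl)carbamoyl)methyl on an aromatic nitrogen

For the measured compounds named here, no measured step shows what this kind of exchange does, so the size of the step from compound 1 to compound 3 in this assay is not anchored by the data. The expectation is a step close to none beyond the scatter, with the value of compound 3 expected near that of compound 1: a 1.2-fold higher number from compound 1 to compound 3 (0.07 log units; within the scatter). For compound 3 the estimated value in this assay is 15000 nM, expected to lie between 4000 nM and 60000 nM.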

Compound 3, half-maximal inhibitory concentration: 26300 nM
Compound 3: the middle estimate sits 1.8-fold (0.24 log units) below what was measured, and the stated range covers the measured number.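

In this assay, among these compounds, the exchange of ((3-chlorophenyl)carbamoyl)methyl for 3-chloro-4-fluorophenyl on the aromatic nitrogen gives the first measured step in this set: a 2.1-fold higher number from compound 1 to compound 3 (0.31 log units; beyond the scatter). It shows that this position responds to the change only modestly, and that compound 3 still gives a measured number (26300 nM) without the carbamoyl-bearing chain, so that chain with its hydrogen-bond donor and acceptor is not required for a measurable result in this assay, although inhibition is weaker without it. Nothing measured here tells which part of the exchange accounts for the step.

The single exchange removes the chain and also alters the substitution on the aromatic ring, so the compounds shown leave open how much of the step belongs to each of these changes. Also open, as far as these compounds go, is how the same nitrogen would respond to a group of another kind, such as a benzyl group, a simple alkyl chain or a chain ending in an amine or a carboxylic acid.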